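Swapping a chlorophenyl for a hydroxymethylphenyl in a cytotoxicity series

This account rests on a few compounds, and the source may have more. Where it says the series, first, only, none or still open, it means among the compounds named here.

Measured so far:
compound 1, `OB1OCc2ccc(-n3cc(Sc4ccc(Cl)c(Cl)c4)c4ccccc43)cc21`: > 10 ug/mL in an ADME assay on L929 cells (Mus musculus) for cytotoxicity, read by resazurin assay, with a stated time of 72 h; on this read-out lower numbers stand for stronger inhibition and higher numbers for weaker inhibition
compound 2, `O=C(c1cccc(Cl)c1)c1ccn(-c2ccc3c(c2)B(O)OC3)c1`: > 10 ug/mL

In this assay compound 1 gives only a limit of the assay, > 10 ug/mL. Compound 2 likewise gives only a limit, > 10 ug/mL. So compound 2 stands where every value shown stands, at the limit of > 10 ug/mL in this assay, at which 2 of the 2 values shown sit, and no actual number is known for either compound.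

Compound 3, `O=C(c1ccc(CO)cc1)c1ccn(-c2ccc3c(c2)B(O)OC3)c1`, has not been measured. It differs from compound 2 in one place: 4-(hydroxymethyl)phenyl in place of 3-chlorophenyl on a carbonyl carbon. Going by the values given here, no step between two measured compounds exists here, so there is nothing to gauge how such a change shifts the read-out. The expected step is therefore a step that the limit leaves unreadable from compound 2 to compound 3, that is, none beyond the usual scatter. For compound 3 the estimate is 15 ug/mL, with a range from 7 ug/mL to 40 ug/mL, and a strong chance that the assay again reports only a limit.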

Compound 3, half-maximal inhibitory concentration: 9.31 ug/mL
Beside the measured number, compound 3's estimate is 1.6-fold (0.21 log units) above it, within the range that was stated.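

In this assay, going by these compounds alone, compound 3 gives 9.31 ug/mL, the first actual number in this small set, so with 4-(hydroxymethyl)phenyl on a carbonyl carbon the read-out falls inside the range the assay can report. The swap from 3-chlorophenyl gives an at least 1.0-fold lower number from compound 2 to compound 3 (0.03 log units; that floor lies within the scatter), which is only a floor on the step and not its true size. The real size of the step stays unknown because compound 2 gives only a limit of the assay: the limit of > 10 ug/mL in this assay, at which 2 of the 3 values shown sit.

The compounds shown leave open whether the number depends on the hydroxymethyl group itself or on its place on the phenyl ring. They also leave open how an amine or a carboxylic acid in place of the hydroxymethyl group would read in this assay.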